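This account rests on a few compounds, and the source may have more. Where it says the series, first, only, none or still open, it means among the compounds named here.

Measured so far:
- Compound 1 `O=C1O/C(=C\Cn2cc(Cc3ccccc3)nn2)C(OCc2ccccc2)=C1OCc1ccccc1`; in a functional assay on HCT-116 cells (Homo sapiens) for antiproliferative activity, read by MTT assay, with a stated time of 24 h (on this read-out higher numbers stand for weaker inhibition and lower numbers for stronger inhibition), compound 1 gives 83100 nM.
- Compound 2 `O=C1NC(O)(CCn2cc(C3=CCCCC3)nn2)C(OCc2ccccc2)=C1OCc1ccccc1`; in this assay compound 2 is reported only as the limit > 100000 nM.
- Compound 3 `CC(C)(C)c1ccc(-c2cn(C/C=C3\OC(=O)C(OCc4ccccc4)=C3OCc3ccccc3)nn2)cc1`; in this assay compound 3 is reported only as the limit > 100000 nM.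

Among the measured compounds shown here, compound 2 thus stands at the limit of > 100000 nM in this assay, at which 2 of the 3 values shown sit, a limit rather than a number, and no step from it can be sized. The compound now in question is compound 4 `O=C1NC(O)(CCn2cc(-c3ccccc3)nn2)C(OCc2ccccc2)=C1OCc1ccccc1`. The change from compound 2 is phenyl in place of cyclohex-1-en-1-yl on an aromatic carbon. For the measured compounds named here, the only measured step, an at least 1.2-fold higher number from compound 1 to compound 3 (0.08 log units; that floor lies within the scatter), also replaces a group on an aromatic carbon of a five-membered aromatic ring with 3 nitrogen, but on the core of compound 1 and with a different pair of groups, and it ends at the limit itself; it bears on the present step only loosely and is within the scatter. No step beyond the scatter is expected in this assay in either direction. Compound 4 is therefore estimated at 150000 nM, with a range from 50000 nM to 500000 nM, and most probably will again be reported only as a limit. The expected step is a step that the limit leaves unreadable from compound 2 to compound 4.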

Compound 4, half-maximal inhibitory concentration: 53400 nM
Compound 4: middle estimate off by 2.8-fold (0.45 log units), on the high side, and the stated range covers the measured number.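

In this assay, phenyl in place of cyclohex-1-en-1-yl on this aromatic carbon gives a measured number on the shared core, with an at least 1.8-fold lower number from compound 2 to compound 4 (0.27 log units; that floor lies within the scatter). That step is only a floor and its true size cannot be read, since compound 2 is reported as a limit: the limit of > 100000 nM in this assay, at which 2 of the 4 values shown sit. The two groups match in heavy atoms and differ in the ring, aromatic against non-aromatic, so this position can return a number within the range of the assay without any change in the count of heavy atoms.

Open is how the core of compound 4 responds to a phenyl carrying an amine or a carboxylic acid, or to benzyl, which is shown only on the core of compound 1. Also open, on these data alone, is how phenyl itself reads on the core of compound 1, so the two cores cannot yet be compared through one shared group.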